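The source may hold more compounds than are shown below. What is called first, only, known or untested is meant among the compounds shown, and "the series" means these compounds.

Measured so far:
- compound 1, `OC(CCn1nc2c(Br)c(Br)c(Br)c(Br)c2n1)c1ccc(F)cc1`, gives 0%
- compound 2, `C[C@@H](O)CCn1nc2c(Br)c(Br)c(Br)c(Br)c2n1`, gives 0%

Both compounds were tested in a functional assay on MCF7 cells (Homo sapiens) for antiproliferative activity, read by MTT assay, with a stated time of 48 h, tested at 100 uM; a higher number here means a weaker effect of the compound at the concentration tested, a lower number a stronger effect. Compound 2 stands level with compound 1 at the digits reported: in this assay compound 1 gives 0% and compound 2 gives 0%, and this pair differs by less than the usual scatter, so the two are treated as equal. The two compounds share the same core, and neither shows a measurable effect at the concentration tested.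

Compound 3, `OCC(O)Cn1nc2c(Br)c(Br)c(Br)c(Br)c2n1`, has not yet been measured. It differs from compound 2 in one place, as counted from the two structures: 1,2-dihydroxyethyl in place of 2-hydroxypropyl on a saturated chain carbon bound to an aromatic nitrogen. Among the measured compounds shown here, no step between measured compounds is available to calibrate such a change, and the one comparison at hand, between compound 1 and compound 2, shows no change at all.

On that basis, compound 3 is expected to stay at the same level, with a step of no change at the digits printed from compound 2 to compound 3 (within the scatter) that does not reach beyond the scatter. The estimate for compound 3 in this assay is 0%, with a range from 0% to 12%.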

Compound 3, a percentage reported as activity, at one concentration (the size of the read-out at that concentration, not a potency): 8%
The estimate for compound 3 lay 8 percentage points below the measured number; low and high end bracket the measured number.
By their numbers in this assay, from the lowest: compounds 1, 2 and 3 (each within the scatter of the next).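

In this assay, among the compounds shown here, the change to 1,2-dihydroxyethyl on a saturated chain carbon bound to an aromatic nitrogen gives a number 8 percentage points higher from compound 2 to compound 3 (within the scatter) and is the first step that can be read between two compounds differing in one place. Here 2-hydroxypropyl, with 1 hydrogen-bond donor, 1 hydrogen-bond acceptor and 1 defined stereocentre, gives way to a group of the same 4 heavy atoms with 2 hydrogen-bond donors, 2 hydrogen-bond acceptors and no defined stereocentre, and this exchange leaves the read-out within the usual scatter of repeated measurements. No measured information is available to explain this outcome.

For the compounds shown here, the result covers only one exchange at this position, made between two small hydroxylated chains at a single concentration, so it cannot show how far the position tolerates change in general. On these data alone, whether an amine, a carboxylic acid or a longer chain such as 3-hydroxybutyl in the same place would move the number beyond the scatter remains open.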